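A few compounds are considered here, and "the series" means these few. Any claim that something is new, unique, unknown or untested is made for them only; others in the source may bear on it.

Working notes on the series.

Compound 1 `C=C(Br)C(=O)Nc1ccc(/C=C/C(=O)c2ccccc2)cc1` is the reference. In a functional assay on FM3A cells (Mus musculus) for antiproliferative activity, with a stated time of 48 h (a higher number here means a weaker inhibitor, a lower number a stronger inhibitor), compound 1 gives 3900 nM. Compound 2 `C=C(Br)C(=O)Nc1ccc(/C=C/C(=O)c2ccc(F)cc2)cc1` differs from compound 1 by fluoro in place of hydrogen on an aromatic carbon, and in this assay compound 2 gives 1200 nM; the step is a 3.3-fold lower number from compound 1 to compound 2 (0.51 log units; beyond the scatter). Compound 3 `Nc1ccc(/C=C/C(=O)c2ccccc2)cc1` differs from compound 1 by hydrogen in place of (1-bromoethenyl)carbonyl on a nitrogen on an aromatic ring, and in this assay compound 3 gives 146000 nM; the step is a 37-fold higher number from compound 1 to compound 3 (1.57 log units; beyond the scatter), and compound 3 thus has the highest number of the three measured. Among the compounds with values here, no step is broken down between compound 2 and compound 3; their two values stand as they are.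

Compound 4 `Nc1ccc(/C=C/C(=O)c2ccc(F)cc2)cc1` has not yet been measured. It differs from compound 3 by fluoro in place of hydrogen on an aromatic carbon. This is the same change that was already made from compound 1 to compound 2, where it gave a 3.3-fold lower number from compound 1 to compound 2 (0.51 log units; beyond the scatter), and the two cores differ by hydrogen in place of (1-bromoethenyl)carbonyl on a nitrogen on an aromatic ring. Whether the change carries over onto the core of compound 3 is not known from the two measured pairs alone. Within the data shown here, on the assumption that it does, a step of about a 3.2-fold lower number from compound 3 to compound 4 (0.51 log units; beyond the scatter) is expected for compound 4, resting on the single earlier step of a 3.3-fold lower number from compound 1 to compound 2 (0.51 log units; beyond the scatter) and on compound 3 at 146000 nM. Compound 4 is therefore estimated at 45000 nM in this assay, with a range from 15000 nM to 130000 nM that allows for the change being weaker or stronger on this core.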

Compound 4, half-maximal inhibitory concentration: 185000 nM
Estimate against measurement, compound 4: 4.1-fold (0.61 log units) below, outside the stated range (above it).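

In this assay, fluoro in place of hydrogen on an aromatic carbon does not carry over from the core of compound 1 to the core of compound 3: there the step is a 1.3-fold higher number from compound 3 to compound 4 (0.10 log units; within the scatter), which leaves the two values within the scatter of each other, and the two steps differ: the same change on two cores in this assay, a 3.3-fold lower number (0.51 log units; beyond the scatter) from compound 1 to compound 2 and a 1.3-fold higher number (0.10 log units; within the scatter) from compound 3 to compound 4, 4.1-fold (0.61 log units) apart, beyond the scatter of two such steps. The same result appears from the other side, since taking the (1-bromoethenyl)carbonyl off the nitrogen gives a 150-fold higher number from compound 2 to compound 4 (2.19 log units; beyond the scatter) in the fluoro pair, and this does not match the step in the pair without fluoro: the same change on two cores in this assay, a 37-fold higher number (1.57 log units; beyond the scatter) from compound 1 to compound 3 and a 150-fold higher number (2.19 log units; beyond the scatter) from compound 2 to compound 4, 4.1-fold (0.61 log units) apart, beyond the scatter of two such steps. So in these four compounds the two changes do not simply add, but this rests on two pairs, one fluoro position and one assay, and it does not show why the cores differ or how any other substituent would transfer.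

Still open, on these data alone, is whether chloro, methoxy or nitrile on the same aromatic carbon would also give a step on the core of compound 1 and none on the core of compound 3. Also open, as far as these compounds go, is whether a plain acetyl or a chloroacetyl on the nitrogen would behave like the (1-bromoethenyl)carbonyl, or like the free amine, in carrying the fluoro step.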